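A few compounds are considered here, and "the series" means these few. Any claim that something is new, unique, unknown or untested is made for them only; others in the source may bear on it.

Of the compounds shown here, three built on a shared core have been measured in a functional assay on U-87MG ATCC cells for antiproliferative activity against U-87 MG (Homo sapiens), read by MTT assay, with a stated time of 72 h; a lower number here means a stronger inhibitor, a higher number a weaker inhibitor. Compound 1 `O=C(Nc1ccc(Oc2ccnc3[nH]ccc23)c(F)c1)c1cc2cccnc2n(-c2ccc(F)cc2)c1=O` gives 620 nM, compound 2 `Cn1ccc2c(Oc3ccc(NC(=O)c4cc5cccnc5n(-c5ccc(F)cc5)c4=O)cc3)ccnc21` gives 2120 nM, and compound 3 `Cn1ccc2c(Oc3ccc(NC(=O)c4cc5cccnc5n(-c5ccc(F)cc5)c4=O)cc3F)ccnc21` gives 1320 nM. Compound 3 thus carries the second highest number of the three. The step nearest to it is a 1.6-fold lower number from compound 2 to compound 3 (0.21 log units; within the scatter), which lies within the scatter, while the furthest is a 2.1-fold higher number from compound 1 to compound 3 (0.33 log units; beyond the scatter), which lies beyond it.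

Compound 4 `Cn1ccc2c(Oc3ccc(NC(=O)c4cc5cccnc5n(-c5ccc(Br)cc5F)c4=O)cc3F)ccnc21` differs from compound 3 by 4-bromo-2-fluorophenyl in place of 4-fluorophenyl on an aromatic nitrogen. Neither measured step touches this part of the structure: one concerns methyl in place of hydrogen on an aromatic nitrogen, the other fluoro in place of hydrogen on an aromatic carbon, and both were modest or within the scatter. For the measured compounds named here, no measured step bears on the change at hand, so there is no basis for expecting a shift in this assay beyond the scatter in either direction. The expected step is therefore a 1.1-fold lower number from compound 3 to compound 4 (0.04 log units; within the scatter), a change of little size. On that basis compound 4 is estimated at 1200 nM, with a range from 400 nM to 3600 nM.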

Compound 4, half-maximal inhibitory concentration: 6470 nM
The estimate for compound 4 lay 5.4-fold (0.73 log units) below the measured number; the measured number lies above the stated range.
By their numbers in this assay, from the lowest: compound 1; then compounds 3 and 2 (each within the scatter of the next); then compound 4.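

For the compounds shown here, the aryl group on the aromatic nitrogen of the shared core proves to be a position that can move the number in this assay: 4-bromo-2-fluorophenyl in place of 4-fluorophenyl gives a 4.9-fold higher number from compound 3 to compound 4 (0.69 log units; beyond the scatter), a step beyond the scatter and the first reading at this place. Among the steps read so far it is the largest, and it runs towards a weaker inhibitor. The data shown offer nothing that accounts for this rise.

From the compounds shown here alone, this single change brings in bromo and a second fluoro together, so how much of the step belongs to each remains open. Also open, going by these compounds, are whether the same change acts alike on the core of compound 1, which has hydrogen rather than methyl on its aromatic nitrogen, and how an amine or a methoxy group on this phenyl ring would read.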